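Removing the Benzyl Ester: What Compound 3 May Show

The source may hold more compounds than are shown below. What is called first, only, known or untested is meant among the compounds shown, and "the series" means these compounds.

Of the compounds shown here, two sharing one core have so far been tested in a functional assay on the whole organism (Tail, strain ICR) with Mus musculus as the target, in the tail flick test, with a stated time of 90 min, at a dose of 25 umol/kg by the oral route; a higher number here means a stronger effect of the compound at the dose given, a lower number a weaker effect. Compound 1 `NCCCC[C@H](NC(=O)CN(c1nc(Cl)nc2[nH]cnc12)C1CC1)C(=O)O` gives 28.8% in this assay. Compound 2 `NC(=O)CC[C@H](NC(=O)CN(c1nc(Cl)nc2[nH]cnc12)C1CC1)C(=O)OCc1ccccc1` gives 42.8% in this assay, the higher of the two numbers, and its gap to compound 1 lies beyond the usual scatter. These two compounds differ in more than one place, so only the two values themselves can be set side by side. Compound 3 `NC(=O)CC[C@H](NC(=O)CN(c1nc(Cl)nc2[nH]cnc12)C1CC1)C(=O)O` has not yet been measured. It differs from compound 2 in a single place: hydrogen in place of benzyl on an oxygen next to a carbonyl group. Put another way, the benzyloxycarbonyl group becomes a carboxy group. Going by the values given here, no measured pair shows this change on its own, so the step can only be estimated. A moderate downward step, close to the edge of the scatter, is expected, giving a number 12.8 percentage points lower from compound 2 to compound 3 (beyond the scatter). Compound 3 is therefore estimated at 30% in this assay, within a range from 12% to 48%.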

Compound 3, a percentage reported as activity, at one dose (the size of the read-out at that dose, not a potency): 41.1%
Estimate against measurement, compound 3: 11.1 percentage points below, and the stated range covers the measured number.
By their numbers in this assay, from the lowest: compound 1; then compounds 3 and 2 (each within the scatter of the next).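

In this assay, hydrogen in place of benzyl on an oxygen next to a carbonyl group gives a number 1.7 percentage points lower from compound 2 to compound 3 (within the scatter), so at this dose the read-out does not depend on keeping the benzyl group and its aromatic ring. The other step, carbamoyl in place of 2-aminoethyl on a saturated chain carbon, three bonds along the chain from an amide-type nitrogen and a carbonyl carbon, gives a number 12.3 percentage points higher from compound 1 to compound 3 (beyond the scatter), and it is the only one of the two that lies beyond the scatter. Nothing shown here explains either step.

Open, going by these compounds, is how a methyl or an ethyl group on that oxygen would read. Also open, on these data alone, is whether a longer chain ending in carbamoyl, or a carboxylic acid in place of carbamoyl, would hold the number of compound 3.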